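The source may report more compounds than this note shows. Statements on the series, on what has been measured and on what is new or still open speak of the compounds shown alone.

Measured so far:
compound 1 `O=[N+]([O-])c1ccc2c(c1)/C(=N\O)C(c1c[nH]c3ccc([N+](=O)[O-])cc13)=N2` gives 8250 nM in a functional assay on HepG2 cells (Homo sapiens) for cytotoxicity, read by MTT assay, with a stated time of 2 days; on this read-out lower numbers stand for stronger inhibition and higher numbers for weaker inhibition
compound 2 `c1ccc(CO/N=C2/C(c3c[nH]c4ccccc34)=Nc3ccccc32)cc1` gives 19500 nM in this assay
compound 3 `Cc1ccc(CO/N=C2/C(c3c[nH]c4ccccc34)=Nc3ccccc32)cc1` gives 19100 nM in this assay

On these numbers compound 3 stands second highest of the three. The step of a 1.0-fold lower number from compound 2 to compound 3 (0.01 log units; within the scatter) is within the scatter, so these two values show no order between them; compound 1 alone sits at a lower number, beyond the scatter.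

Compound 4 `Fc1ccc(CO/N=C2/C(c3c[nH]c4ccccc34)=Nc3ccccc32)cc1` differs from compound 3 by fluoro in place of methyl on an aromatic carbon. Among the measured compounds shown here, the only measured step at this position, a 1.0-fold lower number from compound 2 to compound 3 (0.01 log units; within the scatter), stayed within the scatter, and no measured step exchanges methyl for fluoro, so the expectation for compound 4 in this assay is a step of no more than the scatter, a 1.1-fold lower number from compound 3 to compound 4 (0.03 log units; within the scatter). Compound 4 is therefore estimated at 18000 nM, with a range of 9000 nM to 36000 nM.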

Compound 4, half-maximal inhibitory concentration: 35500 nM
For compound 4 the middle estimate is 2.0-fold (0.29 log units) below the measured one; measured number inside the range.
By their numbers in this assay, from the lowest: compound 1; then compounds 3, 2 and 4 (each within the scatter of the next).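

With fluoro, this position now carries a third substituent, and in this assay neither new step leaves the scatter: (a 1.9-fold higher number from compound 3 to compound 4 (0.27 log units; within the scatter)) and (a 1.8-fold higher number from compound 2 to compound 4 (0.26 log units; within the scatter)). The values of compound 2, compound 3 and compound 4 therefore show no order, so on these compounds this position tolerates hydrogen, methyl and fluoro alike, with no separation yet between 4-methylbenzyl and 4-fluorobenzyl. No evidence bearing on this result is at hand.

Open, as far as these compounds go, is whether an amine or a carboxylic acid at this position would move the number beyond the scatter. From the compounds shown here alone, a longer chain in place of the benzyl group is equally open.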